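Nitro in Place of Methoxy: Expected Paw Edema Inhibition

The source may hold more compounds than are shown below. What is called first, only, known or untested is meant among the compounds shown, and "the series" means these compounds.

Three compounds have been measured in a functional assay on the whole organism (strain Wistar) for inhibition, with Rattus norvegicus as the target, read by paw edema, with a stated time of 2 h, at a dose of 30 mg/kg; on this read-out lower numbers stand for less inhibition and higher numbers for more inhibition at the one dose given (going by the name of the read-out):
- compound 1, `O=C(CN1CCNCC1)Nc1nc2cc([N+](=O)[O-])ccc2s1`, gives 12.3%
- compound 2, `COc1ccc2sc(NC(=O)CN3CCN(c4ccccc4)CC3)nc2c1`, gives 21.7%
- compound 3, `CCN1CCN(CC(=O)Nc2nc3cc(OC)ccc3s2)CC1`, gives 17.4%

Compound 2 carries the highest of the three numbers, yet the other two lie within the usual scatter of it, so no real ordering can be read from them. Among the measured compounds shown here, the only single-place step measured is ethyl in place of phenyl on an amine nitrogen in a ring, which gives a number 4.3 percentage points lower from compound 2 to compound 3 (within the scatter).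

Compound 4, `O=C(CN1CCN(c2ccccc2)CC1)Nc1nc2cc([N+](=O)[O-])ccc2s1`, differs from compound 2 by nitro in place of methoxy on an aromatic carbon. For the measured compounds named here, no measured step exchanges these two groups directly. Compound 1 does carry the nitro group, but it also lacks the phenyl on the ring amine, so its value of 12.3% cannot be tied to the nitro alone. With only this to go on, compound 4 is expected to stay close to compound 2, and the expected step of a number 5.7 percentage points lower from compound 2 to compound 4 (within the scatter) should not exceed the scatter. The estimate for compound 4 in this assay is 16%, expected to fall between 5% and 28%.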

Compound 4, a percentage reported as inhibition, in the whole organism at one dose (the size of the read-out at that dose, not a potency): 34.8%
Compound 4: the middle estimate sits 18.8 percentage points below what was measured, outside the stated range (above it).
By their numbers in this assay, from the lowest: compounds 1, 3 and 2 (each within the scatter of the next); then compound 4.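

Among the compounds shown here, on this aromatic carbon, in this assay, nitro in place of methoxy gives a number 13.1 percentage points higher from compound 2 to compound 4 (beyond the scatter) and so moves the number by more than the usual scatter, which the one earlier step, a number 4.3 percentage points lower from compound 2 to compound 3 (within the scatter), did not do. The phenyl on the ring amine also counts when nitro is present, as adding it in place of hydrogen gives a number 22.5 percentage points higher from compound 1 to compound 4 (beyond the scatter) and shows that this nitrogen's substituent can change the read-out. No measurement shown here explains either rise.

Going by these compounds, it remains open whether the rise is particular to nitro or would also appear with another group on this carbon, such as an amine, a nitrile or a carboxylic acid. On these data alone, it is also open whether nitro would give a similar step with ethyl instead of phenyl on the ring amine.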